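A few compounds are considered here, and "the series" means these few. Any claim that something is new, unique, unknown or untested is made for them only; others in the source may bear on it.

Of the compounds shown here, three built on one shared core have so far been tested in a functional assay on HCT-116 cells (Homo sapiens) for inhibition, read by sulforhodamine B assay, with a stated time of 48 h, tested at 50 uM; on this read-out higher numbers stand for more inhibition of growth at the one concentration tested and lower numbers for less inhibition of growth. Compound 3 `COc1cc(/C=C/C(=O)/C=C/c2cc(OC)c(OC)c(OC)c2)ccc1OCc1cn(CCOc2cc(=O)oc3ccccc23)nn1`, which carries a 3,4,5-trimethoxyphenyl group, gives 89%, the highest of the three numbers. Compound 1 `COc1cc(/C=C/C(=O)/C=C/c2cccs2)ccc1OCc1cn(CCOc2cc(=O)oc3ccccc23)nn1`, with thiophen-2-yl in that place, gives 71%, and compound 2 `COc1cccc(/C=C/C(=O)/C=C/c2ccc(OCc3cn(CCOc4cc(=O)oc5ccccc45)nn3)c(OC)c2)c1`, with 3-methoxyphenyl there, gives 70%.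

Compound 4 `COc1cc(/C=C/C(=O)/C=C/c2ccccc2)ccc1OCc1cn(CCOc2cc(=O)oc3ccccc23)nn1` has not been measured yet. It differs from compound 3 in that same place, on a double-bonded chain carbon bound to a double-bonded chain carbon: phenyl in place of 3,4,5-trimethoxyphenyl on a double-bonded chain carbon bound to a double-bonded chain carbon. All three measured steps change this one position. Going from thiophen-2-yl to 3-methoxyphenyl gives a number 1 percentage points lower from compound 1 to compound 2 (within the scatter), so these two groups cannot be told apart here. Bringing in 3,4,5-trimethoxyphenyl gives a number 18 percentage points higher from compound 1 to compound 3 (beyond the scatter) and likewise a number 19 percentage points higher from compound 2 to compound 3 (beyond the scatter). These two steps are the closest guide, as compound 4 gives up that same group. Phenyl itself is untested, so it is only an assumption that it will behave like the other two groups. On that assumption, a modest fall of similar size is expected in this assay, and the estimated change is a number 20 percentage points lower from compound 3 to compound 4 (beyond the scatter). For compound 4 the estimate is 69%, with an expected range from 55% to 82%.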

Compound 4, percent growth inhibition at one concentration: 56%
Compound 4: the middle estimate sits 13 percentage points above what was measured; low and high end bracket the measured number.
By their numbers in this assay, from the lowest: compound 4; then compounds 2 and 1 (each within the scatter of the next); then compound 3.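

Phenyl turns out not to be interchangeable with the two groups that matched each other in this assay: hydrogen in place of methoxy on the aromatic ring gives a number 14 percentage points lower from compound 2 to compound 4 (beyond the scatter), and phenyl in place of thiophen-2-yl gives a number 15 percentage points lower from compound 1 to compound 4 (beyond the scatter). Giving up 3,4,5-trimethoxyphenyl therefore costs more than the earlier compounds suggested, at a number 33 percentage points lower from compound 3 to compound 4 (beyond the scatter), and among the three compounds with a benzene ring at this place, the number rises from phenyl through 3-methoxyphenyl to 3,4,5-trimethoxyphenyl, a series that compound 1, with its thiophen-2-yl, stands outside. No measurement shown here explains why these groups differ in this way.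

As far as these compounds go, it remains open whether this rise belongs to methoxy itself or would appear with other groups on the ring, such as a hydroxy group, a chlorine atom or an amine, and whether 3,4-dimethoxyphenyl would fall with the 3-methoxyphenyl compound or with compound 3. From the compounds shown here alone, all of these numbers also come from a single concentration, so the order of the compounds at other concentrations is unknown.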